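Swapping the aryl group on the shared core

This account rests on a few compounds, and the source may have more. Where it says the series, first, only, none or still open, it means among the compounds named here.

Two compounds share a common core and differ only in the aryl group attached to it. Compound 1 `Cc1nc(-c2ccc(Cl)s2)sc1COc1ccc2c(c1)OCC2CC(=O)O` gives 8.34% in a functional assay on CHO cells for agonist activity at Free fatty acid receptor 1 (Homo sapiens), read by FLIPR and calcium flux, tested at 100 nM; on this read-out lower numbers stand for a weaker effect and higher numbers for a stronger effect at the one concentration tested. Going by the values given here, compound 2 `Cc1cccc(-c2nc(C)c(COc3ccc4c(c3)OCC4CC(=O)O)s2)c1` gives 47.2% in the same assay, the higher of the two numbers measured so far. Among the compounds with values here, the one measured step, a number 38.9 percentage points higher from compound 1 to compound 2 (beyond the scatter), shows that this position matters.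

Compound 3 `Cc1nc(-c2ccc(F)cc2)sc1COc1ccc2c(c1)OCC2CC(=O)O` differs from compound 2 by one change: 4-fluorophenyl in place of 3-methylphenyl on an aromatic carbon. Within the data shown here, no measured step exchanges one six-membered aromatic ring for another at this position, so the measured step offers only indirect guidance. Because a number 38.9 percentage points higher from compound 1 to compound 2 (beyond the scatter) shows the read-out is sensitive here, a shift is expected for compound 3, and some loss from compound 2 seems plausible as the estimated step of a number 17.2 percentage points lower from compound 2 to compound 3 (beyond the scatter). Compound 3 is therefore estimated at 30%, with a range from 10% to 55%.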

Compound 3, a percentage reported as activity, at one concentration (the size of the read-out at that concentration, not a potency): 61.6%
Estimate against measurement, compound 3: 31.6 percentage points below, outside the stated range (above it).
By their numbers in this assay, from the lowest: compound 1; then compound 2; then compound 3.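

Exchanging 3-methylphenyl for 4-fluorophenyl gives a number 14.4 percentage points higher from compound 2 to compound 3 (beyond the scatter) in this assay, so this position still separates two six-membered aromatic rings with the same count of heavy atoms. The wider step, a number 53.3 percentage points higher from compound 1 to compound 3 (beyond the scatter), shows that 4-fluorophenyl gives the highest number of the three groups, and both phenyl-type groups stand above 5-chlorothiophen-2-yl, although two such groups are too few to make a general pattern. Nothing shown explains why these groups give different numbers.

Compound 2 and compound 3 differ in both the substituent and its place on the ring, which leaves open whether the fluorine itself or its place on the ring matters more. Also open, as far as these compounds go, is how a plain phenyl group, or a phenyl ring carrying an amine or a nitrile, would read at this position.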